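The source may report more compounds than this note shows. Statements on the series, on what has been measured and on what is new or still open speak of the compounds shown alone.

Measured compounds in an ADME assay on microsomes from liver (Rattus norvegicus) for metabolic stability; on this read-out higher numbers stand for a longer-lived compound and lower numbers for a shorter-lived compound:

- compound 1, `CC(C)[C@@H](C[C@H]1SC(=O)NC1=O)c1ccc(-c2ccc3cccc(F)c3c2)[nH]c1=O`: 0.77 h
- compound 2, `C/C(=C1/OC(=O)NC1=O)C(c1ccc(-c2ccc3cccc(F)c3c2)[nH]c1=O)C(C)C`: > 3 h
- compound 3, `CCc1cccc2ccc(-c3ccc(C(/C=C4\OC(=O)NC4=O)(CC)CC)c(=O)[nH]3)cc12`: 1.77 h

As far as these compounds go, compound 2 sits at the limit of > 3 h in this assay, at which 1 of the 3 values shown sits; its figure of > 3 h is a limit of this assay, not a number, so its true half-life is unknown beyond that bound. Of the three, only compound 2 returns a bound of that kind. Compound 1 and compound 3 give numbers: compound 1 at 0.77 h and compound 3 at 1.77 h lie within the usual scatter of each other, so no order is claimed between them. For the measured compounds named here, no single-point step between measured compounds exists in this set.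

Compound 4, `CC(C)C(c1ccc(-c2ccc3cccc(F)c3c2)[nH]c1=O)C1NC(=O)NC1=O`, is the next entry for this assay. Relative to compound 2 it carries a group of 7 heavy atoms (3 carbon, 2 nitrogen, 2 oxygen; one five-membered non-aromatic ring with 2 hetero atoms) in place of a group of 9 heavy atoms (5 carbon, 1 nitrogen, 3 oxygen; one five-membered non-aromatic ring with 2 hetero atoms), on a saturated chain carbon bound to an aromatic carbon and a saturated chain carbon.

With compound 2 known only as a limit, the size of the step from compound 2 to compound 4 cannot be anchored on a number. The expectation is a downward move, of a size beyond the scatter, since the two compounds with a numerical half-life in this series, compound 1 and compound 3, both sit clear below the limit of compound 2.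

For compound 4 the estimate in this assay is 1.5 h, within 0.6 h to 3.5 h, which is expected to correspond to a step of an at least 2.0-fold lower number from compound 2 to compound 4 (0.30 log units; that floor lies within the scatter).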

Compound 4, half-life: 0.145 h
Compound 4: middle estimate off by 10-fold (1.01 log units), on the high side; measured number below the stated range.
By their numbers in this assay, from the lowest: compound 4; then compound 1; then compound 3. At a limit, above all of these: compound 2.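

In this assay, for the compounds shown here, replacing the group on the saturated chain carbon bound to an aromatic carbon and a saturated chain carbon with 2,5-dioxoimidazolidin-4-yl gives an at least 20-fold lower number from compound 2 to compound 4 (1.31 log units; beyond the scatter), the first change in one place that can be read. Compound 2 is known only through a limit, so the step is a floor and not an exact size: the limit of > 3 h in this assay, at which 1 of the 4 values shown sits. The new information is that the half-life responds strongly to the group at this place, even with the rest of the structure held constant and a five-membered non-aromatic ring with 2 hetero atoms present on both sides of the change.

The exchange alters several counted features at once, including ring hetero atoms, double bonds outside aromatic rings and hydrogen-bond donors, so the compounds shown do not assign the step to any one of them. Also open, as far as these compounds go, are the full size of the step and how the half-life would respond to a carboxylic acid or an amine at this place on the same core.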